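Sulfonyl aryl variation in a trifluoromethyl hydroxypropanamide series

This account rests on a few compounds, and the source may have more. Where it says the series, first, only, none or still open, it means among the compounds named here.

Measured compounds:
- compound 1 `COc1ccccc1S(=O)(=O)c1ccc(NC(=O)C(C)(O)C(F)(F)F)cc1`; in a functional assay (Cavia porcellus) with sulfonylurea receptors; K-ATP channels (Homo sapiens) as the target (on this read-out higher numbers stand for weaker inhibition and lower numbers for stronger inhibition), compound 1 gives 1600 nM
- compound 2 `COc1cccc(S(=O)(=O)c2ccc(NC(=O)C(C)(O)C(F)(F)F)cc2)c1`; in this assay compound 2 gives 16000 nM

Compound 2 stands highest of the two numbers; its nearest neighbour is compound 1, and the step of a 10-fold higher number from compound 1 to compound 2 (1.00 log units; beyond the scatter) lies beyond the scatter, so the 3-methoxyphenyl on the sulfonyl sulfur goes with clearly weaker inhibition than the 2-methoxyphenyl.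

Compound 3 `CC(O)(C(=O)Nc1ccc(S(=O)(=O)c2ccccc2Cl)cc1)C(F)(F)F` is not yet measured. It differs from compound 2 by 2-chlorophenyl in place of 3-methoxyphenyl on a sulfonyl sulfur. Within the data shown here, the only measured step that bears on this change is a 10-fold higher number from compound 1 to compound 2 (1.00 log units; beyond the scatter), which swapped 2-methoxyphenyl for 3-methoxyphenyl on the same sulfonyl sulfur. Among the measured compounds shown here, compound 3 brings back a 2-substituted phenyl, but with chlorine rather than methoxy, and no measured pair shows what that exchange does on its own. For the measured compounds named here, the working expectation is that compound 3 moves back toward compound 1, because the step of a 10-fold higher number from compound 1 to compound 2 (1.00 log units; beyond the scatter) is the one change in this set that shifted the number beyond the scatter, with the chlorine-for-methoxy part left open. The expected step is a 6.4-fold lower number from compound 2 to compound 3 (0.81 log units; beyond the scatter). The estimate for compound 3 in this assay is 2500 nM, with a range from 800 nM to 8000 nM.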

Compound 3, half-maximal inhibitory concentration: 2300 nM
Compound 3: middle estimate off by 1.1-fold (0.04 log units), on the high side; the range from low to high includes it.
By their numbers in this assay, from the lowest: compounds 1 and 3 (each within the scatter of the next); then compound 2.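

In this assay, 2-chlorophenyl in place of 3-methoxyphenyl on the sulfonyl sulfur gives a 7.0-fold lower number from compound 2 to compound 3 (0.84 log units; beyond the scatter), so a phenyl group other than 2-methoxyphenyl also lies well under the number of compound 2, although this step changes both the substituent and its numbered place on the phenyl. Chloro in place of methoxy on an aromatic carbon gives a 1.4-fold higher number from compound 1 to compound 3 (0.16 log units; within the scatter), which provides the first direct reading of that exchange and shows that 2-chlorophenyl and 2-methoxyphenyl cannot be told apart in this assay, while 3-methoxyphenyl stands apart from both across these three compounds. No measurement at hand offers a reason for this grouping.

Still open, from the compounds shown here alone, is whether the numbered place or the substituent governs the weak result of compound 2, a question that a 3-chlorophenyl on the sulfonyl sulfur would separate from the two 2-substituted groups. Equally open, going by these compounds, is how far the tolerance for chloro and methoxy extends, for example to an amine, a carboxylic acid or a longer alkoxy chain on the same aromatic carbon.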